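The compounds below may be only part of what the source reports. "The series", "measured", "known", "first", "only" and "open" are said of these compounds alone.

Measured compounds:
- compound 1, `CN1C[C@@H](C(=O)NCc2ccc(Cl)cc2Cl)N(C)C1=O`, with 2 nM in a functional assay on HEK293 cells for antagonist activity at P2X purinoceptor 7 (Homo sapiens); on this read-out higher numbers stand for weaker inhibition and lower numbers for stronger inhibition
- compound 2, `CN1C[C@@H](C(=O)NCc2cccc(Cl)c2Cl)N(C)C1=O`, with 10 nM in this assay

Among the measured compounds shown here, compound 2 holds the higher of the two numbers so far. For the measured compounds named here, its only neighbour is compound 1, whose value lies well below it, a gap that exceeds the usual scatter; no single-point step between the two has been worked out, so only their two values themselves speak.

Compound 3, `CN1C(=O)NC[C@H]1C(=O)NCc1cccc(Cl)c1Cl`, has not yet been measured. It differs from compound 2 in one place: hydrogen in place of methyl on an amide-type nitrogen in a ring. Going by the values given here, no measured pair shows the effect of this change, so its size is unknown from the data. Compound 3 is expected to give a number close to that of compound 2, perhaps somewhat higher, and the step of a 2.0-fold higher number from compound 2 to compound 3 (0.30 log units; within the scatter) is estimated to fall near or just beyond the scatter. On that basis compound 3 is estimated at 20 nM, with a range from 6 nM to 70 nM.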

Compound 3, half-maximal inhibitory concentration: 25.1 nM
The estimate for compound 3 lay 1.3-fold (0.10 log units) below the measured number; low and high end bracket the measured number.
By their numbers in this assay, from the lowest: compound 1; then compound 2; then compound 3.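

In this assay, among the compounds shown here, putting hydrogen in place of methyl on the amide-type nitrogen in the ring gives a 2.5-fold higher number from compound 2 to compound 3 (0.40 log units; beyond the scatter), the first one-place change in this set whose size can be read. The step is modest but lies beyond the scatter, so in this single pair the methyl goes with the lower number, and the nitrogen is a place where a change of just one heavy atom registers in this read-out. No measurement at hand accounts for the shift.

As far as these compounds go, whether the same change would give a step of similar size with the chlorine pattern of compound 1 remains open. So does how an ethyl group or a longer chain ending in an amine on this nitrogen would compare with methyl and hydrogen.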